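The source may hold more compounds than are shown below. What is called first, only, known or untested is meant among the compounds shown, and "the series" means these compounds.

Measured compounds:
compound 1 `CCOC(=O)c1ccc(NC(=O)NCc2ccnnc2)cc1` – > 100000 nM, a limit
compound 2 `CCN(C1CCCC1)S(=O)(=O)c1ccc(NC(=O)NCc2ccncc2)cc1` – 60 nM
compound 3 `CCOC(=O)c1ccc(NC(=O)N(C)Cc2ccncc2)cc1` – > 100000 nM, a limit

Of the compounds shown here, three built on the shared core have been tested in an assay on isolated protein for activation of Nicotinamide phosphoribosyltransferase (Homo sapiens); a lower number here means that less compound is needed, a higher number that more compound is needed for the effect. Compound 2 is the only one of them that returns a number, giving 60 nM in this assay. Compound 1 gives only a limit, > 100000 nM. Compound 3 likewise gives only a limit, > 100000 nM. Going by the values given here, both of those sit at the limit of > 100000 nM in this assay, at which 2 of the 3 values shown sit, so no step between measured compounds can be sized from these data.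

The next compound, compound 4 `CN(C)S(=O)(=O)c1ccc(NC(=O)NCc2ccncc2)cc1`, keeps everything of compound 2 except the group on the sulfonyl sulfur: dimethylamino in place of cyclopentyl(ethyl)amino on a sulfonyl sulfur. Among the compounds with values here, since no measured pair tells how this assay answers to a change at that position, the expectation rests on the change itself. Swapping the larger ring-bearing amine for the small dimethylamino group is expected to cost activity, a step of a 17-fold higher number from compound 2 to compound 4 (1.22 log units; beyond the scatter) from compound 2 to compound 4 in this assay, beyond the usual scatter. Compound 4 is therefore estimated at 1000 nM, with a likely range from 200 nM to 10000 nM.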

Compound 4, half-maximal effective concentration: 3110 nM
The estimate for compound 4 lay 3.1-fold (0.49 log units) below the measured number; the range from low to high includes it.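

In this assay, going by these compounds alone, dimethylamino in place of cyclopentyl(ethyl)amino on a sulfonyl sulfur gives a 52-fold higher number from compound 2 to compound 4 (1.71 log units; beyond the scatter), the first step that can be sized. Within the data shown here, the group on the sulfonyl sulfur therefore clearly affects the number, which the earlier compounds could not show. Even without the five-membered ring, compound 4 still returns a number rather than a limit: the limit of > 100000 nM in this assay, at which 2 of the 4 values shown sit.

This single pair changes the ring and the size of the group together, so it cannot show which of the two accounts for the step. Diethylamino, which has no ring, and cyclopentylamino, which keeps the ring but lacks the ethyl, would help separate the two on the same sulfonyl sulfur.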